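The source may report more compounds than this note shows. Statements on the series, on what has been measured and on what is new or still open speak of the compounds shown alone.

Measured compounds:
- compound 1, `CCCCCCC#Cc1c(CCCCCC)oc2nc(=O)n(Cc3cn(-c4ccc(Cl)cc4)nn3)cc12`, in an ADME assay on WI-38 cells (Homo sapiens) for antiproliferative activity, read by MTT assay, with a stated time of 72 h (a higher number here means a weaker inhibitor, a lower number a stronger inhibitor), gives > 100000 nM, which is a limit of the assay.
- compound 2, `CCCCCCC#Cc1c(CCCCCC)oc2nc(=O)n(Cc3cn(Cc4ccccc4)nn3)cc12`, in this assay gives 23400 nM.
- compound 3, `O=c1nc2oc(CCCCl)cc2cn1Cc1cn(Cc2ccccc2)nn1`, in this assay gives 5200 nM.

Between compound 2 and compound 1 the change is 4-chlorophenyl in place of benzyl on an aromatic nitrogen, and the step is an at least 4.2-fold higher number from compound 2 to compound 1 (0.63 log units; beyond the scatter); it is read only as a bound because compound 1 sits at the limit of > 100000 nM in this assay, at which 1 of the 3 values shown sits. How the core of compound 3 differs from the core of compound 2 is not broken down here; compound 3 simply gives the lower of the two numbers.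

Compound 4, `O=c1nc2oc(CCCCl)cc2cn1Cc1cn(-c2ccc(Cl)cc2)nn1`, carries the same change as compound 1 does, namely (4-chlorophenyl in place of benzyl on an aromatic nitrogen). The step is expected to be a 5.8-fold higher number from compound 3 to compound 4 (0.76 log units; beyond the scatter), resting on the measured at least 4.2-fold higher number from compound 2 to compound 1 (0.63 log units; beyond the scatter). Compound 4 is therefore estimated at 30000 nM, between 8000 nM and 150000 nM.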

Compound 4, half-maximal inhibitory concentration: 72500 nM
Compound 4: the middle estimate sits 2.4-fold (0.38 log units) below what was measured; the range from low to high includes it.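

In this assay, 4-chlorophenyl in place of benzyl on an aromatic nitrogen again raises the number on the second core, with a 14-fold higher number from compound 3 to compound 4 (1.14 log units; beyond the scatter), so the direction of the step carries over in the two pairs shown. Compound 1 gives > 100000 nM, which is a limit of the assay. Whether the change has the same size on both cores is therefore not shown, and two cores establish no rule for the wider series: the same change on two cores in this assay, an at least 4.2-fold higher number (0.63 log units; beyond the scatter) from compound 2 to compound 1 and a 14-fold higher number (1.14 log units; beyond the scatter) from compound 3 to compound 4; the limit leaves it open whether they differ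

The compounds shown leave open how an unsubstituted phenyl or a 4-chlorobenzyl on that nitrogen would read in this assay. They also leave open whether a 4-methoxybenzyl or a 4-fluorophenyl there would follow the same direction on either core.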